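This account rests on a few compounds, and the source may have more. Where it says the series, first, only, none or still open, it means among the compounds named here.

Measured compounds in this series:

Compound 1 `Oc1cccc(-c2cc(-c3cccnc3)nc(-c3cccc(Cl)c3)c2)c1` — "not determined" (no result reported) in a functional assay on T47D cells (Homo sapiens) for cytotoxicity, read by CCK-8 assay and cell counting, with a stated time of 2 days; on this read-out higher numbers stand for weaker inhibition and lower numbers for stronger inhibition.
Compound 2 `Oc1ccc(-c2cc(-c3ccc(Cl)cc3)nc(-c3cccnc3)c2)cc1` — 29300 nM.
Compound 3 `Oc1cccc(-c2cc(-c3ccc(Cl)cc3)nc(-c3cccnc3)c2)c1` — 18100 nM.

Compound 3 holds the lower of the two numbers reported in this assay; its nearest neighbour is compound 2, and the difference a 1.6-fold lower number from compound 2 to compound 3 (0.21 log units; within the scatter) lies within the scatter, so the two cannot be ordered. Compound 1 carries no result.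

Compound 4 `Oc1cccc(-c2cc(-c3ccccc3)nc(-c3ccc(Cl)cc3)c2)c1` differs from compound 3 in one place: phenyl in place of pyridin-3-yl on an aromatic carbon. Going by the values given here, no measured step bears on this exchange; the only measured step, a 1.6-fold lower number from compound 2 to compound 3 (0.21 log units; within the scatter), concerns the hydroxyphenyl group and was within the scatter. With nothing to anchor the exchange of pyridin-3-yl for phenyl, the expectation for compound 4 in this assay is a step of a 1.0-fold lower number from compound 3 to compound 4 (0.00 log units; within the scatter) that is not beyond the scatter. Compound 4 is therefore estimated at 18000 nM, with a range from 6000 nM to 55000 nM to cover the unknown effect of this change.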

Compound 4, half-maximal inhibitory concentration: 11300 nM
For compound 4 the middle estimate is 1.6-fold (0.20 log units) above the measured one; low and high end bracket the measured number.
By their numbers in this assay, from the lowest: compounds 4, 3 and 2 (each within the scatter of the next, the first and the last beyond it).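

In this assay, going by these compounds alone, the first exchange at this position, on the aromatic carbon next to the ring nitrogen, gives a 1.6-fold lower number from compound 3 to compound 4 (0.20 log units; within the scatter) and so cannot be told apart from no effect. Phenyl in place of pyridin-3-yl takes away the ring nitrogen and the hydrogen-bond acceptor counted for that group, and compound 4 still gives a number in the same range as compound 3, so this nitrogen is not shown to be needed for a number of this size. Nothing at hand explains the result.

Going by these compounds, whether a different group at this position, such as an amine, a carboxylic acid or a longer alkyl chain, would give a step beyond the scatter stays open. Also open, on these data alone, is whether the exchange of pyridin-3-yl for phenyl reads the same with 4-hydroxyphenyl in place of 3-hydroxyphenyl.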